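Furan-2-yl in place of 3,4-dihydroxyphenyl: notes on compound 4

A few compounds are considered here, and "the series" means these few. Any claim that something is new, unique, unknown or untested is made for them only; others in the source may bear on it.

In a functional assay on MCF7 cells (Homo sapiens) for cytotoxicity, read by MTT assay, with a stated time of 48 h (a higher number here means a weaker inhibitor, a lower number a stronger inhibitor), compound 1 `O=C(CSc1nnc(-c2ccncc2)o1)N/N=C/c1ccccc1[N+](=O)[O-]` gives 35600 nM and compound 2 `O=C(CSc1nnc(-c2ccncc2)o1)N/N=C/c1ccccc1O` gives 4750 nM while compound 3 `O=C(CSc1nnc(-c2ccncc2)o1)N/N=C/c1ccc(O)c(O)c1` gives 910 nM as the lowest of the three numbers. The next structure is compound 4 `O=C(CSc1nnc(-c2ccncc2)o1)N/N=C/c1ccco1` with furan-2-yl in place of 3,4-dihydroxyphenyl on a carbon with a double bond to nitrogen. Two measured changes at this same place bear on it: the modest 5.2-fold lower number from compound 2 to compound 3 (0.72 log units; beyond the scatter) and the large 39-fold lower number from compound 1 to compound 3 (1.59 log units; beyond the scatter) while the modest 7.5-fold lower number from compound 1 to compound 2 (0.87 log units; beyond the scatter) points the same way. In these three compounds the number falls as hydroxy groups appear on the aromatic ring. For the measured compounds named here, compound 4 has no hydroxy group there, like compound 1 at 35600 nM but no measured compound carries a five-membered ring, so the size of the step stays uncertain. A modest to large move to a higher number is expected, with the estimated step being a 5.5-fold higher number from compound 3 to compound 4 (0.74 log units; beyond the scatter) in this assay as a working figure. The expected value for compound 4 is 5000 nM with an estimated range from 1300 nM to 25000 nM for repeat measurements.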

Compound 4, half-maximal inhibitory concentration: 16600 nM
Compound 4: middle estimate off by 3.3-fold (0.52 log units), on the low side; low and high end bracket the measured number.
By their numbers in this assay, from the lowest: compound 3; then compound 2; then compound 4; then compound 1.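

In this assay, furan-2-yl on the carbon with a double bond to nitrogen places compound 4 on the weaker side of both hydroxy-bearing compounds, with an 18-fold higher number from compound 3 to compound 4 (1.26 log units; beyond the scatter) and a 3.5-fold higher number from compound 2 to compound 4 (0.54 log units; beyond the scatter) in the two comparisons. The presence of hydroxy groups alone does not settle the order, however: compound 1 and compound 4 both lack them and still differ, with a 2.1-fold lower number from compound 1 to compound 4 (0.33 log units; beyond the scatter) favouring the furan-2-yl ring. Nothing at hand gives a reason for these differences.

Furan-2-yl differs from 3,4-dihydroxyphenyl in ring size, ring oxygen and hydroxy groups all at once, so the share of each in the step stays unresolved. An unsubstituted phenyl, a 4-hydroxyphenyl or a thiophen-2-yl ring would bear on that question, and an amine on the ring remains an open comparison with hydroxy.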